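The compounds below may be only part of what the source reports. "The series", "measured", "known", "first", "only" and "open" are said of these compounds alone.

Compound 1 `COc1cc(C2Oc3cc([C@H]4Oc5cc(O)cc(O)c5C(=O)[C@@H]4O)ccc3OC2COC(=O)c2ccccc2)ccc1O` gives 105000 nM in a functional assay, read by spectrophotometry, with a stated time of 30 min; a higher number here means that more compound is needed for the effect, a lower number that less compound is needed.
Compound 2 `COc1cc(C2Oc3cc([C@H]4Oc5cc(O)cc(O)c5C(=O)[C@@H]4O)ccc3OC2COC(=O)c2cccc(Cl)c2)ccc1O` gives 106000 nM in this assay.
Compound 3 `CCOC(=O)CC(=O)OCC1Oc2ccc([C@H]3Oc4cc(O)cc(O)c4C(=O)[C@@H]3O)cc2OC1c1ccc(O)c(OC)c1` gives 101000 nM in this assay.

Compound 3 has the lowest of the three numbers, yet every gap is within the scatter: a 1.0-fold lower number from compound 1 to compound 3 (0.02 log units; within the scatter) and a 1.0-fold lower number from compound 2 to compound 3 (0.02 log units; within the scatter). Compound 4 `COc1cc(C2Oc3cc([C@H]4Oc5cc(O)cc(O)c5C(=O)[C@@H]4O)ccc3OC2COC(=O)c2cc(N)cc([N+](=O)[O-])c2)ccc1O` differs from compound 3 by 3-amino-5-nitrophenyl in place of (ethoxycarbonyl)methyl on a carbonyl carbon. Going by the values given here, two measured steps bear on this position: exchanging the group on that carbonyl carbon gave a 1.0-fold lower number from compound 1 to compound 3 (0.02 log units; within the scatter) and a 1.0-fold lower number from compound 2 to compound 3 (0.02 log units; within the scatter), and adding a substituent to an aromatic ring there gave a 1.0-fold higher number from compound 1 to compound 2 (0.00 log units; within the scatter), none beyond the scatter. The expected step in this assay is therefore a 1.0-fold higher number from compound 3 to compound 4 (0.01 log units; within the scatter), no direction beyond the scatter. Compound 4 is estimated at 103000 nM, in a range from 50000 nM to 210000 nM.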

Compound 4, half-maximal effective concentration: > 300000 nM
Compound 4: only a limit was reported; the forecaster's own chance of this, stated with the estimate: 10%; middle value at least 2.9-fold (0.46 log units) from the limit.
By their numbers in this assay, from the lowest: compounds 3, 1 and 2 (each within the scatter of the next). At a limit, above all of these: compound 4.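

Going by these compounds alone, earlier exchanges on this carbonyl carbon stayed within the scatter, but 3-amino-5-nitrophenyl is the first group there to give a step beyond it. The reading for compound 4 is a limit and not a number, so only a minimum size can be given for its steps: an at least 2.9-fold higher number from compound 3 to compound 4 (0.47 log units; beyond the scatter) and an at least 2.8-fold higher number from compound 2 to compound 4 (0.45 log units; beyond the scatter) and an at least 2.8-fold higher number from compound 1 to compound 4 (0.45 log units; beyond the scatter) in this assay's terms. The position therefore does respond to the group it carries. The compounds shown leave open how large the true step is. They also leave open whether the amino or the nitro group goes with it, which an aminophenyl or a nitrophenyl group alone on this carbonyl carbon could separate.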